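A few compounds are considered here, and "the series" means these few. Any claim that something is new, unique, unknown or untested is made for them only; others in the source may bear on it.

Compound 1 `N/C(=N\NC(=S)N1CCCCCC1)c1ccccn1`: 72.3%
Compound 2 `Cc1cccc(/C(N)=N/NC(=S)N2CCCCCC2)n1`: 63.5%

In a functional assay on A-431 cells (Homo sapiens) for cytotoxicity, read by MTT assay, with a stated time of 72 h, tested at 30 uM (on this read-out lower numbers stand for less inhibition of growth and higher numbers for more inhibition of growth at the one concentration tested), compound 1 gives 72.3%, and compound 2 gives 63.5%, a step of a number 8.8 percentage points lower from compound 1 to compound 2 (within the scatter). Compound 3 `N/C(=N\NC(=S)N1CCCCCC1)c1ccc(F)cn1` differs from compound 1 by fluoro in place of hydrogen on an aromatic carbon. Within the data shown here, the only measured step, methyl in place of hydrogen on an aromatic carbon, stayed within the scatter, and no step with fluoro entering has been measured. On that basis no change beyond the scatter is expected, a number 0.3 percentage points lower from compound 1 to compound 3 (within the scatter). Compound 3 is therefore estimated to give 72%, most likely between 55% and 85%.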

Compound 3, percent growth inhibition at one concentration: 81.3%
Estimate against measurement, compound 3: 9.3 percentage points below; measured number inside the range.
By their numbers in this assay, from the lowest: compounds 2, 1 and 3 (each within the scatter of the next, the first and the last beyond it).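

In this assay, fluoro in place of hydrogen on an aromatic carbon, two atoms from the ring nitrogen and para to a large group, gives a number 9 percentage points higher from compound 1 to compound 3 (within the scatter), so growth inhibition stays within the scatter of compound 1. This position of the core therefore tolerates a fluoro, at least in this one-concentration test. Nothing measured here gives a reason for the result. Going by these compounds, whether a chlorine, a methoxy group or an amine at this same place would also hold the read-out stays open.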